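From acetoxy to (propylcarbonyl)oxy: compound 2 to compound 3

The source may hold more compounds than are shown below. What is called first, only, known or untested is meant among the compounds shown, and "the series" means these compounds.

In a functional assay on Vero cells (Chlorocebus sabaeus) for cytotoxicity (on this read-out higher numbers stand for weaker inhibition and lower numbers for stronger inhibition), compound 1 `Nc1nc(=O)n([C@H]2C=C[C@@H](CO)O2)cc1I` gives > 100000 nM, which is a limit of the assay. Compound 2 `CC(=O)OC[C@@H]1C=C[C@H](n2cc(F)c(N)nc2=O)O1` gives > 100000 nM, also a limit. Both values shown thus sit at one limit (the limit of > 100000 nM in this assay, at which 2 of the 2 values shown sit), and compound 2 has no numeric value. Compound 3 `CCCC(=O)OC[C@@H]1C=C[C@H](n2cc(F)c(N)nc2=O)O1` carries ethyl in place of hydrogen on a saturated chain carbon bound to a carbonyl carbon. Among the compounds with values here, no measured step exists for this change. The expected change in this assay, a step that the limit leaves unreadable from compound 2 to compound 3, stays within the scatter, with no expected direction. Compound 3 is estimated at 120000 nM, with an expected range from 50000 nM to 200000 nM.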

Compound 3, half-maximal inhibitory concentration: > 100000 nM
Compound 3: a limit, no number; the forecaster's own chance of this, stated with the estimate: 85%; the middle value is on the limit's open side.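

In this assay no step can be read between compound 2 and compound 3, as both values are limits: the limit of > 100000 nM in this assay, at which 3 of the 3 values shown sit. The compounds shown leave open whether acetoxy to (propylcarbonyl)oxy changes the read-out at all, and at what concentration any of them would inhibit.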